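Chloro to trifluoromethyl on the fused core of compound 2

This account rests on a few compounds, and the source may have more. Where it says the series, first, only, none or still open, it means among the compounds named here.

Measured compounds:
compound 1 `CCn1cc(Nc2ncc3ccn(-c4ccc(OC)cc4)c3n2)cn1`: 405 nM
compound 2 `Clc1nn(-c2ccc3ncccc3c2)c2nc(Nc3cnn(C4CCNCC4)c3)ncc12`: 5 nM

In an assay on isolated protein for inhibition of eIF-2-alpha kinase GCN2 (Homo sapiens) (on this read-out lower numbers stand for stronger inhibition and higher numbers for weaker inhibition), compound 1 gives 405 nM, while compound 2 gives 5 nM, the lowest of the two numbers in this assay and beyond the scatter relative to compound 1. Among the measured compounds shown here, the two measured compounds differ at many places at once, so no single-point step between them can be read off.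

Compound 3 `FC(F)(F)c1nn(-c2ccc3ncccc3c2)c2nc(Nc3cnn(C4CCNCC4)c3)ncc12` differs from compound 2 in one place: trifluoromethyl in place of chloro on an aromatic carbon. Nothing in the measured pair tells how this particular exchange acts in this assay; the expectation therefore rests on the close resemblance of compound 3 to compound 2. For compound 3 the step from compound 2 is expected to be small, a 2.0-fold higher number from compound 2 to compound 3 (0.30 log units; within the scatter), toward a slightly higher number or none beyond the scatter. Compound 3 is estimated at 10 nM in this assay, with a range from 3 nM to 40 nM.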

Compound 3, half-maximal inhibitory concentration: 168 nM
For compound 3 the middle estimate is 17-fold (1.23 log units) below the measured one; the whole stated range lies below it.
By their numbers in this assay, from the lowest: compound 2; then compound 3; then compound 1.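

This position is not indifferent to its substituent: in this assay, with the rest of the molecule unchanged, trifluoromethyl in place of chloro gives a 34-fold higher number from compound 2 to compound 3 (1.53 log units; beyond the scatter) on the carbon of the five-membered aromatic ring. The exchange of one heavy atom for four at this carbon therefore weakens inhibition well beyond the scatter, and of the two groups seen here, chloro gives the stronger inhibition. No measurement at hand bears on the reason for this step.

Two groups at one carbon cannot show whether the read-out follows the heavy-atom count or depends on the particular group, and methyl, bromo or nitrile at this carbon would help separate those readings. On these data alone, it also remains open whether the step keeps its size when another group, such as a simple phenyl, replaces the quinolin-6-yl group.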